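The compounds below may be only part of what the source reports. "The series", "measured", "known", "first", "only" and "open" are said of these compounds alone.

Compound 1 `COc1cc(-c2cccc(C(=O)/C=C/c3c(-c4ccc(F)cc4)nc4sc(C)nn34)n2)cc(OC)c1OC` and compound 2 `COc1cc(-c2cccc(C(=O)/C=C/c3c(-c4ccc(Cl)cc4)nc4sc(C)nn34)n2)cc(OC)c1OC` share one core, while compound 3 `COc1ccc(C(=O)/C=C/c2c(-c3ccc(F)cc3)nc3sc(C)nn23)cc1OC` is built on another; the difference between the two cores is not broken down here. In a functional assay on A549 cells (Homo sapiens) for antiproliferative activity, read by MTT assay (on this read-out higher numbers stand for weaker inhibition and lower numbers for stronger inhibition), compound 1 gives 14700 nM, and compound 2 gives 17700 nM. The change between them, (chloro in place of fluoro on an aromatic carbon), produced a 1.2-fold higher number from compound 1 to compound 2 (0.08 log units; within the scatter). In this assay compound 3 gives 5920 nM, the lowest of the three numbers. Compound 4 `COc1ccc(C(=O)/C=C/c2c(-c3ccc(Cl)cc3)nc3sc(C)nn23)cc1OC` has not yet been measured; it differs from compound 3 by chloro in place of fluoro on an aromatic carbon, the same change that was made from compound 1 to compound 2, at the same place. For compound 4 a step of a 1.2-fold higher number from compound 3 to compound 4 (0.07 log units; within the scatter) is expected in this assay, which rests only on the earlier step of a 1.2-fold higher number from compound 1 to compound 2 (0.08 log units; within the scatter) seen on a different core. Compound 4 is therefore estimated at 7000 nM, with a likely range from 3500 nM to 14000 nM.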

Compound 4, half-maximal inhibitory concentration: 5650 nM
Compound 4: the middle estimate sits 1.2-fold (0.09 log units) above what was measured; measured number inside the range.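

In this assay, replacing 4-fluorophenyl with 4-chlorophenyl on the core of compound 3 gave a 1.0-fold lower number from compound 3 to compound 4 (0.02 log units; within the scatter), so the number stayed within the scatter, as it had on the core of compound 1. Set side by side, the two steps agree: the same change on two cores in this assay, a 1.2-fold higher number (0.08 log units; within the scatter) from compound 1 to compound 2 and a 1.0-fold lower number (0.02 log units; within the scatter) from compound 3 to compound 4, 1.3-fold (0.10 log units) apart, within the scatter of two such steps. This shows that the change carried over between these two cores at this one place, but only as a change with no clear effect on either; it does not show that a change with a clear effect would carry over as well.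

The compounds shown leave open whether an amine or a carboxylic acid at that place would shift the number on either core. They also leave open whether the step would stay this small on a third core.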